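The source may hold more compounds than are shown below. What is called first, only, known or untested is meant among the compounds shown, and "the series" means these compounds.

Measured compounds:
compound 2 `CO/N=C(\C)CN1CCN(c2c(F)cc3c(=O)c(C(=O)O)cn(C4CC4)c3c2OC)CC1C` — 49.6 ug/mL
compound 3 `CCO/N=C(\C)CN1CCN(c2c(F)cc3c(=O)c(C(=O)O)cn(C4CC4)c3c2OC)CC1C` — 31.3 ug/mL
compound 1 `CCOC(=O)CCN1CCN(c2c(F)cc3c(=O)c(C(=O)O)cn(C4CC4)c3c2OC)CC1C` — "not determined" (no result reported)

Among the compounds with values here, in an ADME assay on Vero cells (Chlorocebus sabaeus) for cytotoxicity, read by MTT assay, with a stated time of 72 h (a lower number here means that less compound is tolerated, a higher number that more compound is tolerated), compound 2 gives 49.6 ug/mL and compound 3 gives 31.3 ug/mL; the single measured step, a 1.6-fold lower number from compound 2 to compound 3 (0.20 log units; within the scatter), is the only comparison the series offers. Compound 1 has no number in this assay, so it stands nowhere on the scale; only its structure is known. Compound 4 `COc1c(N2CCN(CC/C(C)=N/Nc3ccccc3)C(C)C2)c(F)cc2c(=O)c(C(=O)O)cn(C3CC3)c12` differs from it as follows: a group of 10 heavy atoms (8 carbon, 2 nitrogen; one six-membered aromatic ring of carbon only) in place of a group of 5 heavy atoms (3 carbon, 2 oxygen; no ring), on a saturated chain carbon, two bonds along the chain from an amine nitrogen in a ring. Within the data shown here, no measured step touches this change: the step between compound 2 and compound 3 concerns a different part of the chain and lies within the scatter, so it gives no direction. The expectation therefore rests only on compounds 2 and 3 sharing the same core and ring substitution. Compound 4 is expected to give about 30 ug/mL in this assay, within 10 ug/mL to 80 ug/mL.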

Compound 4, half-maximal cytotoxic concentration: 62.5 ug/mL
Compound 4: middle estimate off by 2.1-fold (0.32 log units), on the low side; the measured number falls inside the stated range.
By their numbers in this assay, from the lowest: compounds 3, 2 and 4 (each within the scatter of the next).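

In this assay a group carrying a six-membered aromatic ring of carbon only, on a saturated chain carbon bound to an amine nitrogen in a ring, brings no shift beyond the scatter (a 2.0-fold higher number from compound 3 to compound 4 (0.30 log units; within the scatter) and a 1.3-fold higher number from compound 2 to compound 4 (0.10 log units; within the scatter)). Within the data shown here, the earlier step changed only the end of a chain, so this is the first sign that a much larger group with a ring can sit at this place without moving the number beyond the scatter. Nothing available explains this result. From the compounds shown here alone, whether an amine or a carboxylic acid at this place would also stay within the scatter remains open. Compound 1, with its ethoxycarbonyl group, still has no place on the scale.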